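Replacing the chloro of compound 1 with a piperidinylethoxy chain

This account rests on a few compounds, and the source may have more. Where it says the series, first, only, none or still open, it means among the compounds named here.

Among the compounds with values here, compound 1 `Cc1cnc(C(=O)Nc2cc(Cl)cc3cccnc23)cn1` is the only compound with a number in a functional assay on BXPC-3 cells (Homo sapiens) for inhibition, read by MTT assay, with a stated time of 72 h (on this read-out lower numbers stand for stronger inhibition and higher numbers for weaker inhibition), where compound 1 gives 5200 nM. Compound 2 `O=C(Nc1cc(Cl)cc2cccnc12)c1ncccn1` reaches only a limit of this assay, > 10000 nM, so an at least 1.9-fold higher number from compound 1 to compound 2 (0.28 log units; that floor lies within the scatter) rests on that floor (the limit of > 10000 nM in this assay, at which 1 of the 2 values shown sits). Compound 3 `Cc1cnc(C(=O)Nc2cc(OCCC3CCNCC3)cc3cccnc23)cn1` differs from compound 1 at another place: 2-(piperidin-4-yl)ethoxy in place of chloro on an aromatic carbon. Within the data shown here, no measured step touches this aromatic carbon, so the account has nothing that bears on this change. Compound 3 is therefore expected to stay near compound 1, with a 1.3-fold lower number from compound 1 to compound 3 (0.11 log units; within the scatter) as the estimate. For compound 3 the estimated value in this assay is 4000 nM, between 800 nM and 20000 nM.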

Compound 3, half-maximal inhibitory concentration: 8330 nM
The estimate for compound 3 lay 2.1-fold (0.32 log units) below the measured number, within the range that was stated.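

At this aromatic carbon, this assay now gives a first measured step: a 1.6-fold higher number from compound 1 to compound 3 (0.20 log units; within the scatter). Within the data shown here, a 2-(piperidin-4-yl)ethoxy chain, with its six-membered non-aromatic ring, can therefore replace the single chlorine of compound 1 with no change beyond the scatter. Nothing shown bears on a cause for this step.

Going by these compounds, what a shorter chain, a methoxy group or an open-chain amine would give at this carbon stays open. So does whether a morpholine ring at the end of the chain would read the same as the piperidine.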